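Hydroxyl in place of chloro on a Toll-like receptor 8 amide

The source may hold more compounds than are shown below. What is called first, only, known or untested is meant among the compounds shown, and "the series" means these compounds.

Compounds measured so far:
compound 1, `O=C(Nc1ccc(Oc2cc(C(F)(F)F)cc(C(F)(F)F)c2)cc1)c1ccccc1F`, 3000 nM
compound 2, `O=C(Nc1ccc(Oc2cc(C(F)(F)F)cc(C(F)(F)F)c2)cc1)c1cc(Cl)ccc1F`, 1110 nM

Both compounds were tested in an assay on HEK293 cells for inhibition of Toll-like receptor 8 (Homo sapiens), with a stated time of 16 h; a lower number here means a stronger inhibitor, a higher number a weaker inhibitor. Compound 1 gives 3000 nM, and compound 2 gives 1110 nM. Among the compounds with values here, the one step in hand, a 2.7-fold lower number from compound 1 to compound 2 (0.43 log units; beyond the scatter), is the only guide to how the aromatic ring on the carbonyl carbon responds to substitution. Within the data shown here, compound 2 thus stands as the lower of the two numbers, with compound 1 as its only neighbour.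

Compound 3, `O=C(Nc1ccc(Oc2cc(C(F)(F)F)cc(C(F)(F)F)c2)cc1)c1ccc(O)cc1F`, has not been tested. It differs from compound 2 as follows: 2-fluoro-4-hydroxyphenyl in place of 5-chloro-2-fluorophenyl on a carbonyl carbon. Among the measured compounds shown here, the change removes the chloro whose arrival gave a 2.7-fold lower number from compound 1 to compound 2 (0.43 log units; beyond the scatter), so that part of the step is expected to reverse, and no measured compound shows what the hydroxyl brings. The expectation for compound 3 is therefore a number near that of compound 1, with a 2.7-fold higher number from compound 2 to compound 3 (0.43 log units; beyond the scatter) as the estimated step, and with wide uncertainty. Compound 3 is estimated at 3000 nM, in the range 1000 nM to 9000 nM.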

Compound 3, half-maximal inhibitory concentration: > 50000 nM
Compound 3 gave a limit, no number; the forecaster's own chance of this, stated with the estimate: 10%; at least 16-fold (1.22 log units) between middle value and limit.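

In this assay compound 3 gives a limit and not a number: the limit of > 50000 nM in this assay, at which 1 of the 3 values shown sits. Within the data shown here, the ring on the carbonyl carbon proves far more sensitive than the earlier compounds showed: 2-fluoro-4-hydroxyphenyl in place of 5-chloro-2-fluorophenyl gives an at least 45-fold higher number from compound 2 to compound 3 (1.65 log units; beyond the scatter), and the hydroxyl added on its own gives an at least 16-fold higher number from compound 1 to compound 3 (1.22 log units; beyond the scatter). Losing the chloro cannot be the whole story, as compound 1 has no chloro and still gives 3000 nM, so the hydroxyl itself carries a cost that is much larger than the modest gain of a 2.7-fold lower number from compound 1 to compound 2 (0.43 log units; beyond the scatter).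

The compounds shown leave open whether this loss follows the free hydroxyl or its place on the ring, and whether a methoxy group or an amine in the same place would fare any better. They also leave the true size of the loss unknown, and they do not say why the hydroxyl has this effect.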